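Fluorine Removal on the Benzyl Arm: Expecting Compound 4

This account rests on a few compounds, and the source may have more. Where it says the series, first, only, none or still open, it means among the compounds named here.

Four compounds share a common core and differ in two respects: where the side chain joins the central ring, and whether a fluorine sits on the benzyl group. Compound 1 `C=C(Br)C(=O)Nc1ccc(/C=C2\SC(=O)N(Cc3ccccc3)C2=O)cc1` carries a plain benzyl group, and in a functional assay on HeLa cells (Homo sapiens) for cytotoxicity, read by cell counting, with a stated time of 4 days (a higher number here means a weaker inhibitor, a lower number a stronger inhibitor), compound 1 gives 1000 nM. Compound 2 `C=C(Br)C(=O)Nc1ccc(/C=C2\SC(=O)N(Cc3ccc(F)cc3)C2=O)cc1` carries a 4-fluorobenzyl group, and compound 2 gives 2000 nM. The change from compound 2 to compound 1 is hydrogen in place of fluoro on an aromatic carbon, and it made a 2.0-fold lower number from compound 2 to compound 1 (0.30 log units; within the scatter). Compound 3 `C=C(Br)C(=O)Nc1cccc(/C=C2\SC(=O)N(Cc3ccc(F)cc3)C2=O)c1` has the same atoms as compound 2 joined differently; the difference between the two cores is not broken down here. Compound 3 gives 800 nM, which lies within the scatter of compound 1 and beyond the scatter from compound 2. Compound 4 `C=C(Br)C(=O)Nc1cccc(/C=C2\SC(=O)N(Cc3ccccc3)C2=O)c1` differs from compound 3 by hydrogen in place of fluoro on an aromatic carbon, the same change as before, as the place descriptions agree word for word. Because the earlier step of a 2.0-fold lower number from compound 2 to compound 1 (0.30 log units; within the scatter) stayed within the scatter, a step of similar size is expected here, a 1.3-fold lower number from compound 3 to compound 4 (0.12 log units; within the scatter). Compound 4 is therefore estimated at 600 nM, most likely between 250 nM and 1500 nM.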

Compound 4, half-maximal inhibitory concentration: 1400 nM
Estimate against measurement, compound 4: 2.3-fold (0.37 log units) below, within the range that was stated.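

Putting hydrogen in place of fluoro on the benzyl group gives a 1.8-fold higher number from compound 3 to compound 4 (0.24 log units; within the scatter) in this assay and so does not repeat what the same change did on the core of compound 1. Each step taken alone stays within the scatter, so neither one is a firm effect by itself, and nothing here explains why the two cores part ways or shows how the change would behave on a third core. What the comparison does show is that, among these four compounds, a step read on one core cannot simply be carried over to the other, since the two steps point in opposite directions and the gap between them is larger than the scatter allows: the same change on two cores in this assay, a 2.0-fold lower number (0.30 log units; within the scatter) from compound 2 to compound 1 and a 1.8-fold higher number (0.24 log units; within the scatter) from compound 3 to compound 4, 3.5-fold (0.54 log units) apart, beyond the scatter of two such steps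

As far as these compounds go, it remains open whether another group in the place of fluoro, such as chloro, methoxy or a carboxylic acid, would also behave differently on the two cores. From the compounds shown here alone, it is equally open whether a longer chain in place of the benzyl group would show the same split.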